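From Dimethylamino to Benzamido on the Chain

This account rests on a few compounds, and the source may have more. Where it says the series, first, only, none or still open, it means among the compounds named here.

Values from a functional assay on HCT-116 cells (Homo sapiens) for cytotoxicity, read by MTT assay, with a stated time of 72 h (a lower number here means a stronger inhibitor, a higher number a weaker inhibitor), stand as follows.

- Compound 1 `O=C(NCc1ccc(F)cc1)c1nc(Br)c2cccnc2c1NCc1ccc(F)cc1` gives > 20000 nM (a limit)
- Compound 2 `CN(C)CCCNc1c(C(=O)NCc2ccc(F)cc2)nc(Br)c2cccnc12` gives > 10000 nM (a limit)
- Compound 3 `N[C@H]1CC[C@H](Nc2c(C(=O)NCc3ccc(F)cc3)nc(Br)c3cccnc23)CC1` gives 4000 nM (a number)

Compound 2 stands only at the limit > 10000 nM and has no number. Compound 4 `O=C(NCCCNc1c(C(=O)NCc2ccc(F)cc2)nc(Br)c2cccnc12)c1ccccc1` puts benzamido in place of dimethylamino on a saturated chain carbon, three bonds along the chain from a nitrogen on an aromatic ring, and the count reads benzamido in place of dimethylamino on a saturated chain carbon, three bonds along the chain from a nitrogen on an aromatic ring for this change.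

The steps of an at least 5.0-fold lower number from compound 1 to compound 3 (0.69 log units; beyond the scatter) and an at least 2.5-fold lower number from compound 2 to compound 3 (0.39 log units; beyond the scatter) both bring in 4-aminocyclohexyl, which compound 4 does not carry, while the case of a step that the two limits leave unreadable from compound 1 to compound 2 gives no size. Compound 1 carries 4-fluorobenzyl on a nitrogen on an aromatic ring, and its > 20000 nM is also a limit. No step beyond the scatter is therefore expected, in either direction, in this assay for this change. The expected step is a step that the limit leaves unreadable from compound 2 to compound 4 on this estimate. Compound 4 is estimated at 12000 nM with an expected range of 4000 nM to 35000 nM and may return only a limit.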

Compound 4, half-maximal inhibitory concentration: > 10000 nM
Compound 4: only a limit was reported; the forecaster's own chance of this, stated with the estimate: 55%; the middle value lies beyond the limit too.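

In this assay compound 4 gives > 10000 nM, a limit and not a number. Among these compounds, compound 1 and compound 2 also stand at limits, and no step to compound 4 can be read from either. The compounds shown leave open whether benzamido and dimethylamino differ at all on this chain.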